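Aryl swaps at the benzylamide end of the series

This account rests on a few compounds, and the source may have more. Where it says the series, first, only, none or still open, it means among the compounds named here.

Three amides sharing one core have been measured. Compound 1 `CC(C)Cc1ccc(C(C)C(=O)NCc2ccc(Cl)cc2)cc1` gives 27000 nM in an assay on brain for inhibition of Fatty-acid amide hydrolase 1 (Rattus norvegicus), read by scintillation counting, with a stated time of 10 min; a lower number here means a stronger inhibitor, a higher number a weaker inhibitor. Compound 2 `COc1ccccc1CNC(=O)C(C)c1ccc(CC(C)C)cc1` gives 18000 nM in this assay, and compound 3 `COc1ccc(CNC(=O)C(C)c2ccc(CC(C)C)cc2)cc1O` gives 18000 nM in this assay. Compound 2 and compound 3 stand together at the lowest numbers of the three, level at the digits recorded, and compound 1 stands a short way higher; the move a 1.5-fold lower number from compound 1 to compound 2 (0.18 log units; within the scatter) is within the scatter, so the three compounds are best read as a flat set.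

Compound 4 `CC(C)Cc1ccc(C(C)C(=O)NCc2ccc(Cl)c(Cl)c2)cc1` has not yet been measured in this assay. It differs from compound 2 as follows: 3,4-dichlorophenyl in place of 2-methoxyphenyl on a saturated chain carbon bound to an amide-type nitrogen. For the measured compounds named here, the only measured step that bears on this change is from compound 1 to compound 2, where the 4-chlorophenyl gave way to 2-methoxyphenyl with no movement beyond the scatter. Going by the values given here, compound 4 carries a second chlorine beyond what compound 1 carries, and no measured pair shows what that adds. The expected step of a 1.2-fold higher number from compound 2 to compound 4 (0.09 log units; within the scatter) is therefore small, toward the number of compound 1 if anywhere. For compound 4 the estimate in this assay is 22000 nM, with a range of 8000 nM to 60000 nM.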

Compound 4, half-maximal inhibitory concentration: 36000 nM
Estimate against measurement, compound 4: 1.6-fold (0.21 log units) below; the measured number falls inside the stated range.
By their numbers in this assay, from the lowest: compounds 2, 3, 1 and 4 (each within the scatter of the next).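

In this assay, 3,4-dichlorophenyl in place of 2-methoxyphenyl on a saturated chain carbon bound to an amide-type nitrogen gives a 2.0-fold higher number from compound 2 to compound 4 (0.30 log units; within the scatter), and chloro in place of hydrogen on an aromatic carbon gives a 1.3-fold higher number from compound 1 to compound 4 (0.12 log units; within the scatter). Both steps lie within the scatter, so the second chlorine, which no earlier pair covered, does not take the series out of its flat reading, and no aryl group shown at this position separates from the others. Nothing available explains this flatness.

From the compounds shown here alone, whether any change at this position can move the number beyond the scatter stays open. A carboxylic acid or an amine on this aryl group, or a longer chain in place of the saturated chain carbon, would test that.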